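This account rests on a few compounds, and the source may have more. Where it says the series, first, only, none or still open, it means among the compounds named here.

Of the compounds shown here, two have so far been measured in a functional assay (Platelet, plasma) for inhibition, with Homo sapiens as the target; a higher number here means a weaker inhibitor, a lower number a stronger inhibitor. Compound 1 `CC1(C(=O)NS(=O)(=O)Cc2ccccc2)CCN(c2nc3c(cc2C#N)C(=O)OC3)CC1` gives 6680 nM in this assay, while compound 2 `N#Cc1cc2c(nc1N1CCC(F)(C(=O)NS(=O)(=O)c3ccc(Cl)s3)CC1)COC2=O` gives 37100 nM. Compound 2 therefore stands at the higher of the two numbers, and its gap to compound 1 lies beyond the scatter of repeated measurements. Compound 3 `N#Cc1cc2c(nc1N1CCC(F)(C(=O)NS(=O)(=O)Cc3ccccc3)CC1)COC2=O` has not yet been measured. It differs from compound 2 in a single place: benzyl in place of 5-chlorothiophen-2-yl on a sulfonyl sulfur. For the measured compounds named here, no pair of measured compounds isolates exactly this change, so the expectation rests on compound 1, which carries the same benzyl group on its sulfonyl sulfur and gives 6680 nM in this assay. On that ground a clear drop in the number is expected, a 3.7-fold lower number from compound 2 to compound 3 (0.57 log units; beyond the scatter), though the second point of difference between compound 1 and compound 2 leaves the size uncertain. Compound 3 is estimated to give 10000 nM in this assay, within a range from 3000 nM to 35000 nM.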

Compound 3, half-maximal inhibitory concentration: 1210 nM
Beside the measured number, compound 3's estimate is 8.3-fold (0.92 log units) above it, outside the stated range (below it).
By their numbers in this assay, from the lowest: compound 3; then compound 1; then compound 2.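

In this assay, for the compounds shown here, the exchange of 5-chlorothiophen-2-yl for benzyl on a sulfonyl sulfur can now be read directly, as a 31-fold lower number from compound 2 to compound 3 (1.49 log units; beyond the scatter), a large step that no earlier pair isolated. With benzyl held in place, fluoro in place of methyl on a saturated ring carbon can also be read, as a 5.5-fold lower number from compound 1 to compound 3 (0.74 log units; beyond the scatter), a modest step, so the change on the sulfonyl sulfur is the larger of the two. No evidence is available on what lies behind either step.

As far as these compounds go, it remains open whether a phenyl or a 2-phenylethyl group on the sulfonyl sulfur would give a number closer to that of compound 3. The compounds also leave open how a hydroxyl group on the saturated ring carbon would compare with fluoro and methyl.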